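Methyl to methoxy on two related cores

The source may report more compounds than this note shows. Statements on the series, on what has been measured and on what is new or still open speak of the compounds shown alone.

Two pairs of compounds share one small change. Compound 1 `Cc1ccc(/C=C2\CCC/C(=C\c3cccc([N+](=O)[O-])c3)C2=O)cc1` and compound 2 `COc1ccc(/C=C2\CCC/C(=C\c3cccc([N+](=O)[O-])c3)C2=O)cc1` differ only in methoxy in place of methyl on an aromatic carbon. In a functional assay on HSC-2 cells (Homo sapiens) for cytotoxicity, with a stated time of 24 h (on this read-out higher numbers stand for lower toxicity in this test and lower numbers for higher toxicity in this test), compound 1 gives 17000 nM, and compound 2 gives 4800 nM, so this change made a 3.5-fold lower number from compound 1 to compound 2 (0.55 log units; beyond the scatter). Compound 3 `Cc1ccc(/C=C2\CCC/C(=C\c3ccc([N+](=O)[O-])cc3)C2=O)cc1` is built from the same atoms as compound 1, joined differently; the difference between the two cores is not broken down here. In this assay compound 3 gives 6600 nM. Compound 4 `COc1ccc(/C=C2\CCC/C(=C\c3ccc([N+](=O)[O-])cc3)C2=O)cc1` has not yet been measured; it stands to compound 3 as compound 2 stands to compound 1, the change being (methoxy in place of methyl on an aromatic carbon). Among the measured compounds shown here, both changes sit at the same place on the same kind of ring, so the step seen between compound 1 and compound 2 is the only guide, and it comes from one pair alone. The number for compound 4 is expected to be 2200 nM, with a range from 900 nM to 5500 nM. The change is expected to make a 3.0-fold lower number from compound 3 to compound 4 (0.48 log units; beyond the scatter), about the size of the earlier step, and this expectation is held loosely.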

Compound 4, half-maximal cytotoxic concentration: > 400000 nM
Compound 4: no number, only a limit; the forecaster's own chance of this, stated with the estimate: 0%; middle value at least 180-fold (2.25 log units) away from the limit.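

In this assay, methoxy in place of methyl did not carry over from one core to the other: it gave a 3.5-fold lower number from compound 1 to compound 2 (0.55 log units; beyond the scatter), but an at least 60-fold higher number from compound 3 to compound 4 (1.78 log units; beyond the scatter). The two steps point in opposite directions, and the gap between them is too wide to put down to ordinary variation between repeated measurements: the same change on two cores in this assay, a 3.5-fold lower number (0.55 log units; beyond the scatter) from compound 1 to compound 2 and an at least 60-fold higher number (1.78 log units; beyond the scatter) from compound 3 to compound 4, at least 210-fold (2.33 log units) apart, beyond the scatter of two such steps. Among the compounds shown here, compound 4 gives > 400000 nM, which is a limit of the assay and not a number, so the full size of its step stays unknown, and with only one pair on each core the result shows that the step cannot simply be transferred, not why the two cores differ.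

The compounds shown leave open whether this split is peculiar to methoxy or would also appear with other groups in the same place, such as ethoxy, a chlorine atom or a dimethylamino group. They also leave open whether further pairs on these two cores would follow compound 1 and compound 2 or compound 3 and compound 4.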